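The source may hold more compounds than are shown below. What is called first, only, known or untested is meant among the compounds shown, and "the series" means these compounds.

Three compounds have been measured so far:

Compound 1, `COc1nc(N)nc2c1c(-c1ccccc1)cn2[C@@H]1O[C@H](CO)[C@@H](O)[C@H]1O`, gives > 20000 nM; this is a limit of the assay, not a number.
Compound 2, `CNc1ncnc2c1c(-c1ccsc1)cn2[C@@H]1O[C@H](CO)[C@@H](O)[C@H]1O`, gives > 20000 nM, again a limit.
Compound 3, `O=c1[nH]cnc2c1c(-c1cc3ccccc3o1)cn2[C@@H]1O[C@H](CO)[C@@H](O)[C@H]1O`, gives > 20000 nM, also a limit.

All three readings come from a functional assay on CCRF-CEM cells (Homo sapiens), read by MTT assay, with a stated time of 72 h; on this read-out lower numbers stand for stronger inhibition and higher numbers for weaker inhibition. Compound 3 therefore does not stand apart from the other two: its result is the same limit, and with nothing but limits in view no order among the three can be drawn. The evidence is summed up by the limit of > 20000 nM in this assay, at which 3 of the 3 values shown sit.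

Compound 4, `O=c1[nH]cnc2c1c(-c1cccs1)cn2[C@@H]1O[C@H](CO)[C@@H](O)[C@H]1O`, has not yet been measured. It keeps the shared core of compound 3 and exchanges one group: thiophen-2-yl in place of 1-benzofuran-2-yl on an aromatic carbon. The group that enters is the smaller one, a single five-membered ring in place of a fused pair of rings. For the measured compounds named here, no step between measured compounds is available to show what such an exchange does here, and the readings on compound 1 and compound 2 show that other groups on that aromatic carbon also reached only the limit. The expectation is therefore that this assay will again show no measurable inhibition, with no step beyond the scatter: the expected step is a step that the limit leaves unreadable from compound 3 to compound 4. Compound 4 is expected to give 30000 nM, within a range from 8000 nM to 100000 nM, and most likely reported once more as a limit.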

Compound 4, half-maximal inhibitory concentration: > 20000 nM
Compound 4: no number, only a limit; the forecaster's own chance of this, stated with the estimate: 85%; the middle value is on the limit's open side.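

In this assay compound 4 gives > 20000 nM, which is a limit and not a number. For the compounds shown here, compound 3 also gave only a limit, so no step between compound 3 and compound 4 can be read. What the compounds shown leave open is whether any group on that aromatic carbon gives a measurable value, since all of them rest at one reading: the limit of > 20000 nM in this assay, at which 4 of the 4 values shown sit.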